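Trimming the nitrogen substituent of compound 1

The source may report more compounds than this note shows. Statements on the series, on what has been measured and on what is new or still open speak of the compounds shown alone.

Compound 1 `CN1CCN(c2ccc(Nc3ncc4nc(Nc5ccc(F)cc5)n([C@H]5CCCN(C(=O)CO)C5)c4n3)cc2)CC1` gives 1.8 nM
Compound 2 `CN1CCN(c2ccc(Nc3ncc4nc(Nc5ccccc5)n([C@H]5CCN(C(=O)OC(C)(C)C)C5)c4n3)cc2)CC1` gives 110 nM
Compound 3 `CN1CCN(c2ccc(Nc3ncc4nc(Nc5ccccc5)n([C@@H]5CCNC5)c4n3)cc2)CC1` gives 65 nM

In a functional assay on HCC827 cells (Homo sapiens) for antiproliferative activity, read by MTT assay, with a stated time of 72 h (a lower number here means a stronger inhibitor, a higher number a weaker inhibitor), compound 1 has the lowest number of the three, beyond the scatter from both others. Compound 4 `CN1CCN(c2ccc(Nc3ncc4nc(Nc5ccc(F)cc5)n([C@H]5CCNC5)c4n3)cc2)CC1` keeps its (4-fluorophenyl)amino group but has pyrrolidin-3-yl in place of 1-((hydroxymethyl)carbonyl)piperidin-3-yl on an aromatic nitrogen as its change. Within the data shown here, no measured step makes this exact swap. The only one, a 1.7-fold lower number from compound 2 to compound 3 (0.23 log units; within the scatter) as measured, bears on it indirectly and stays among pyrrolidines. Compound 3, with pyrrolidin-3-yl but no fluorine, gives 65 nM in this assay and so points to a clear rise. The expected change is a 22-fold higher number from compound 1 to compound 4 (1.35 log units; beyond the scatter) as a rough estimate. Compound 4 is expected near 40 nM within an estimated range of 10 nM to 150 nM.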

Compound 4, half-maximal inhibitory concentration: 1220 nM
Compound 4: the middle estimate sits 31-fold (1.48 log units) below what was measured, outside the stated range (above it).
By their numbers in this assay, from the lowest: compound 1; then compounds 3 and 2 (each within the scatter of the next); then compound 4.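

In this assay, the position on the aromatic nitrogen proved highly sensitive: with the (4-fluorophenyl)amino group kept, pyrrolidin-3-yl in place of 1-((hydroxymethyl)carbonyl)piperidin-3-yl gives a 680-fold higher number from compound 1 to compound 4 (2.83 log units; beyond the scatter). The earlier step at this nitrogen, a 1.7-fold lower number from compound 2 to compound 3 (0.23 log units; within the scatter), had stayed among pyrrolidines and showed no such sensitivity. Nothing available explains the size of the new step.

This step changes the ring and removes the acyl group together, so the compounds shown do not separate the two. From the compounds shown here alone, whether either change alone carries the loss stays open, and a plain piperidin-3-yl or a 1-((hydroxymethyl)carbonyl)pyrrolidin-3-yl group would bear on that question.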